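The source may report more compounds than this note shows. Statements on the series, on what has been measured and on what is new or still open speak of the compounds shown alone.

Measured compounds:

Compound 1 `Cc1cccc(COc2ccc(-c3cc(CN4CCN(Cc5ccc(C(F)(F)F)cc5)CC4)no3)cc2)c1`: 4000 nM
Compound 2 `Cc1cc(C)cc(COc2ccc(-c3cc(CN4CCN(Cc5ccc(C(F)(F)F)cc5)CC4)no3)cc2)c1`: 1600 nM
Compound 3 `N#Cc1ccccc1COc1ccc(-c2cc(CN3CCN(Cc4ccc(C(F)(F)F)cc4)CC3)no2)cc1`: 4000 nM

All three were tested in a functional assay on MCF7 cells (Homo sapiens) for antiproliferative activity, read by sulforhodamine B assay, with a stated time of 72 h; a lower number here means a stronger inhibitor, a higher number a weaker inhibitor. Compound 3 stands level with compound 1, and the two together give the highest numbers of the three; the step of no change at the digits printed from compound 1 to compound 3 (within the scatter) shows no change, while the step of a 2.5-fold higher number from compound 2 to compound 3 (0.40 log units; beyond the scatter) is the only gap beyond the scatter. Compound 2 differs from compound 1 only by the step of a 2.5-fold lower number from compound 1 to compound 2 (0.40 log units; beyond the scatter), a single methyl added to the pendant ring.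

Compound 4 `COc1ccc(COc2ccc(-c3cc(CN4CCN(Cc5ccc(C(F)(F)F)cc5)CC4)no3)cc2)cc1` is the next member. The change from compound 3 is 4-methoxyphenyl in place of 2-cyanophenyl on a saturated chain carbon bound to an oxygen on an aromatic ring. For the measured compounds named here, two measured steps bear on this kind of swap of the pendant ring: no change at the digits printed from compound 1 to compound 3 (within the scatter) and a 2.5-fold higher number from compound 2 to compound 3 (0.40 log units; beyond the scatter). Both were either flat or modest, so exchanging one such ring for another has so far moved the number by a small amount at most. Going by the values given here, the 4-methoxyphenyl group is new here, and no measured compound carries it, so its own effect is unknown. The expectation for compound 4 is therefore a step of a 1.3-fold lower number from compound 3 to compound 4 (0.12 log units; within the scatter), which is expected to stay within or just at the edge of the scatter. Compound 4 is expected to give about 3000 nM, with a likely range from 1200 nM to 8000 nM.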

Compound 4, half-maximal inhibitory concentration: 1300 nM
Estimate against measurement, compound 4: 2.3-fold (0.36 log units) above, and the stated range covers the measured number.
By their numbers in this assay, from the lowest: compounds 4 and 2 (each within the scatter of the next); then compounds 1 and 3 (each within the scatter of the next).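

In this assay, the 4-methoxyphenyl group on the saturated chain carbon gives a lower number than two of the other rings, as shown by the step of a 3.1-fold lower number from compound 3 to compound 4 (0.49 log units; beyond the scatter) and the step of a 3.1-fold lower number from compound 1 to compound 4 (0.49 log units; beyond the scatter). The lower end of this short series therefore does not need two methyl groups on the ring: the step of a 1.2-fold lower number from compound 2 to compound 4 (0.09 log units; within the scatter) leaves the 4-methoxyphenyl and 3,5-dimethylphenyl compounds indistinguishable, although one ring carries a single substituent and the other carries two. No measurement of any property of these groups bears on this result.

The compounds shown leave open whether the lower number belongs to the methoxy group itself or to where it sits on the ring, a question that 2-methoxyphenyl and 3-methoxyphenyl rings could help settle. They also leave open how this place would respond to a ring carrying a carboxylic acid or an amine, since every pendant ring here bears only methyl, nitrile or methoxy groups.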